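Swapping the Methyl Pattern on the Benzyl Group

This account rests on a few compounds, and the source may have more. Where it says the series, first, only, none or still open, it means among the compounds named here.

Measured so far:
Compound 1 `Cc1ccc(Cn2c(=O)cc(C)n(C3C=CC(OC(=O)c4ccccc4)C3)c2=O)cc1` — 20000 nM
Compound 2 `O=C(OC1C=CC(n2ccc(=O)[nH]c2=O)C1)c1ccccc1` — > 250000 nM
Compound 3 `O=C(OC1C=CC(n2ccc(=O)n(Cc3cc(F)cc(F)c3)c2=O)C1)c1ccccc1` — 32000 nM

In an ADME assay on CCRF-CEM cells (Homo sapiens) for cytotoxicity, with a stated time of 3 days (on this read-out lower numbers stand for higher toxicity in this test and higher numbers for lower toxicity in this test), compound 1 gives the lower of the two measured numbers, yet its gap to compound 3 lies within the scatter, so the two cannot be ranked. Compound 2 shows only an assay limit, (the limit of > 250000 nM in this assay, at which 1 of the 3 values shown sits). Among the compounds with values here, the one measured step, an at least 7.8-fold lower number from compound 2 to compound 3 (0.89 log units; beyond the scatter), concerns adding a whole benzyl group rather than altering its methyl pattern, so it bears only loosely on the change to compound 4 `Cc1cc(C)cc(Cn2c(=O)cc(C)n(C3C=CC(OC(=O)c4ccccc4)C3)c2=O)c1`: 3,5-dimethylphenyl in place of 4-methylphenyl on a saturated chain carbon bound to an aromatic nitrogen. A step of this kind is expected to stay within the scatter, so compound 4 is expected near compound 1, with no change at the digits printed from compound 1 to compound 4 (within the scatter). Compound 4 is thus estimated at 20000 nM, within 8000 nM to 50000 nM.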

Compound 4, half-maximal cytotoxic concentration: 25000 nM
Compound 4: middle estimate off by 1.3-fold (0.10 log units), on the low side; the range from low to high includes it.
By their numbers in this assay, from the lowest: compounds 1, 4 and 3 (each within the scatter of the next). At a limit, above all of these: compound 2.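

In this assay, the methyl pattern on this benzyl group makes no readable difference: 3,5-dimethylphenyl in place of 4-methylphenyl gives a 1.3-fold higher number from compound 1 to compound 4 (0.10 log units; within the scatter). This place, on a saturated chain carbon bound to an aromatic nitrogen, thus accepts a second methyl with the read-out staying within the scatter, a finer test than the whole-group step, an at least 7.8-fold lower number from compound 2 to compound 3 (0.89 log units; beyond the scatter). Nothing shown offers a reason for this result. Still open, from the compounds shown here alone, is whether a phenyl ring bearing an amine or a carboxylic acid, or a longer chain in place of the benzyl group, would stay in the same range.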